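This account rests on a few compounds, and the source may have more. Where it says the series, first, only, none or still open, it means among the compounds named here.

Of the compounds shown here, three built on one shared core have been measured in an assay on mitochondria from L6 cells (Rattus norvegicus) for activation, with a stated time of 90 min; a higher number here means that more compound is needed for the effect, a lower number that less compound is needed. Compound 1 `Oc1nc2nonc2nc1Nc1ccc(SC(F)(F)F)cc1` gives 1400 nM. Compound 2 `CCCCc1ccc(Nc2nc3nonc3nc2O)cc1` gives 2100 nM, and compound 3 `CCCCCCc1ccc(Nc2nc3nonc3nc2O)cc1` gives 4700 nM, the highest of the three numbers. Both steps leading into compound 3 raise the number: a 3.4-fold higher number from compound 1 to compound 3 (0.53 log units; beyond the scatter), and a 2.2-fold higher number from compound 2 to compound 3 (0.35 log units; beyond the scatter). The remaining step, a 1.5-fold higher number from compound 1 to compound 2 (0.18 log units; within the scatter), stays within the scatter.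

Compound 4 `Oc1nc2nonc2nc1Nc1ccc(OC(F)(F)C(F)F)cc1` is the next compound to be measured in this assay. Its change from compound 3 is 1,1,2,2-tetrafluoroethoxy in place of hexyl on an aromatic carbon. For the measured compounds named here, the steps that bear on this change are the two into compound 3, of which the one from compound 1 was the larger. The entering 1,1,2,2-tetrafluoroethoxy group, like the (trifluoromethyl)sulfanyl group of compound 1, carries fluorine, whereas the hexyl chain that leaves carried none. The expectation is therefore that compound 4 moves back toward the number of compound 1, a modest decrease rather than none beyond the scatter. This amounts to an expected step of a 2.6-fold lower number from compound 3 to compound 4 (0.42 log units; beyond the scatter). Compound 4 is expected to give 1800 nM, with a range from 800 nM to 4000 nM.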

Compound 4, half-maximal effective concentration: 7000 nM
Compound 4: the middle estimate sits 3.9-fold (0.59 log units) below what was measured; the whole stated range lies below it.
By their numbers in this assay, from the lowest: compounds 1 and 2 (each within the scatter of the next); then compounds 3 and 4 (each within the scatter of the next).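

In this assay, the exchange of the hexyl chain for 1,1,2,2-tetrafluoroethoxy on this aromatic carbon reads as a 1.5-fold higher number from compound 3 to compound 4 (0.17 log units; within the scatter), so at this position a chain of carbon only and a group carrying oxygen and fluorine cannot be told apart in this pair. Carrying fluorine does not by itself hold the number close to that of compound 1: two fluorine-bearing groups are separated by a 5.0-fold higher number from compound 1 to compound 4 (0.70 log units; beyond the scatter), the largest step among the four compounds, and the comparison with the butyl compound gives a 3.3-fold higher number from compound 2 to compound 4 (0.52 log units; beyond the scatter). No measurement at hand offers an explanation for how these groups fall relative to one another.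

The compounds shown leave open how the oxygen and the fluorine of 1,1,2,2-tetrafluoroethoxy each count, a question that a plain ethoxy group at the same place would help to separate. Also open, from the compounds shown here alone, is how an amine or a carboxylic acid on this aromatic carbon would compare with these groups, and whether a chain longer than hexyl would continue the step seen from butyl to hexyl.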